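The compounds below may be only part of what the source reports. "The series", "measured", "known", "first", "only" and "open" are said of these compounds alone.

The measured compounds:
Compound 1, `O=C(CCl)Nc1ccc(SCC(=O)Nc2ccc(Cl)cn2)cc1`, gives 2500 nM in a functional assay on HeLa cells (Homo sapiens) for antiproliferative activity, read by MTT assay, with a stated time of 48 h; a lower number here means a stronger inhibitor, a higher number a weaker inhibitor.
Compound 2, `O=C(CCl)Nc1ccc(SCC(=O)Nc2cccc(Cl)c2)cc1`, reaches only a limit in this assay, > 80000 nM, which is a limit and not a number.
Compound 3, `O=C(CCl)Nc1ccc(SCC(=O)Nc2ccc(Cl)cc2)cc1`, likewise reaches only a limit in this assay, > 80000 nM, again a limit and not a number.

Among the measured compounds shown here, compound 1 therefore stands alone as the only finished number among the three; the other two sit at the limit of > 80000 nM in this assay, at which 2 of the 3 values shown sit. Both steps away from compound 1 are large: an at least 32-fold higher number from compound 1 to compound 2 (1.50 log units; beyond the scatter), and an at least 32-fold higher number from compound 1 to compound 3 (1.50 log units; beyond the scatter). Between the two limits, a step that the two limits leave unreadable from compound 2 to compound 3.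

Compound 4, `O=C(CSc1ccc(NC(=O)C(Cl)(Cl)Cl)cc1)Nc1ccc(Cl)cn1`, differs from compound 1 at a different place: trichloromethyl in place of chloromethyl on a carbonyl carbon. For the measured compounds named here, none of the measured steps touch that carbonyl carbon; all three concern the group on the amide-type nitrogen, which compound 4 keeps exactly as in compound 1. The measured steps thus give no size and no direction for this change, and the estimate rests on compound 1 alone, with wide uncertainty. Compound 4 is expected to give about 20000 nM in this assay, within a range of 3000 nM to 80000 nM. That estimate means an expected step of an 8.0-fold higher number from compound 1 to compound 4 (0.90 log units; beyond the scatter).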

Compound 4, half-maximal inhibitory concentration: > 80000 nM
Compound 4: a limit, no number; the forecaster's own chance of this, stated with the estimate: 40%; middle value at least 4.0-fold (0.60 log units) away from the limit.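

Among the compounds shown here, compound 4 shows that the carbonyl end of the molecule also matters in this assay, a place the earlier steps did not touch: trichloromethyl in place of chloromethyl on the carbonyl carbon gives an at least 32-fold higher number from compound 1 to compound 4 (1.50 log units; beyond the scatter). The earlier compounds shown here showed such a loss only for changes on the other amide-type nitrogen, whereas here the 5-chloropyridin-2-yl group stays in place and the change at the carbonyl carbon alone is enough. Compound 1 remains the only compound with a finished number, and the rest of the series now stands at a limit: the limit of > 80000 nM in this assay, at which 3 of the 4 values shown sit.

As far as these compounds go, the true size of this step stays open, as compound 4 gives a limit and not a number. Also open, from the compounds shown here alone, is whether a methyl, a dichloromethyl, a bromomethyl or a longer chain on that carbonyl carbon would give a finished number in this assay.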